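Swapping a cyclopentyl for a cyanophenyl on the bombesin scaffold

A few compounds are considered here, and "the series" means these few. Any claim that something is new, unique, unknown or untested is made for them only; others in the source may bear on it.

Three compounds share a core in which a carboxylic acid on one aromatic ring, a second aromatic ring and an imidazole carrying a side arm are joined by short carbon chains. In an in vitro functional assay on cells for agonist activity at Bombesin receptor subtype-3 (Homo sapiens), read by luminescence and calcium flux (a higher number here means that more compound is needed for the effect, a lower number that less compound is needed), compound 1 `CCCCc1cnc(C(C)Cc2ccc(-c3ccccc3C(=O)O)cc2)[nH]1` gives 2760 nM, and compound 2 `CCCCc1cnc(CCCc2ccc(-c3ccccc3C(=O)O)cc2)[nH]1` gives 5600 nM. Compound 3 `O=C(O)c1ccccc1-c1ccc(CCc2ncc(CC3CCCC3)[nH]2)cc1` gives 133 nM, the lowest of the three numbers, with compound 1 the nearest and compound 2 the furthest, both beyond the scatter, so compound 3 needs the least compound for the effect.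

Compound 4 `N#Cc1cccc(Cc2cnc(CCc3ccc(-c4ccccc4C(=O)O)cc3)[nH]2)c1` has not yet been measured. The change is 3-cyanophenyl in place of cyclopentyl on a saturated chain carbon bound to an aromatic carbon. No comparable change is available among the measured compounds, so the direction rests on this pair alone. My expectation for compound 4 is that the step of a 1.9-fold higher number from compound 3 to compound 4 (0.27 log units; within the scatter) will be modest, most likely a small rise that may not clear the scatter. Compound 4 is therefore estimated at 250 nM, with a range from 50 nM to 1200 nM.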

Compound 4, half-maximal effective concentration: 812 nM
Compound 4: the middle estimate sits 3.2-fold (0.51 log units) below what was measured; measured number inside the range.
By their numbers in this assay, from the lowest: compound 3; then compound 4; then compound 1; then compound 2.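

In this assay, putting 3-cyanophenyl in place of cyclopentyl on a saturated chain carbon bound to an aromatic carbon gives a 6.1-fold higher number from compound 3 to compound 4 (0.79 log units; beyond the scatter) and so shows that this position does not treat the two groups alike. Going by these compounds alone, the side arm is therefore more than a passive attachment here, since changing only this group moves the number beyond the scatter. Nothing shown here explains the size of this step.

The change replaces a saturated ring with an aromatic one and adds a nitrile in a single move, so the compounds shown cannot say which of these accounts for the rise. A plain benzyl group, which is the same aromatic ring without the nitrile, would separate the two, and a cyclohexylmethyl group would test a larger saturated ring.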